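The compounds below may be only part of what the source reports. "The series", "measured", "known", "first", "only" and "open" are said of these compounds alone.

Working notes on the series: in a functional assay on HT-29 cells (Homo sapiens) (on this read-out higher numbers stand for an effect only at larger amounts of compound and lower numbers for an effect already at smaller amounts), compound 1 `CNC(=O)c1ccc(-c2cc(C(=O)N[C@H]3CCCNC3)c(NC(N)=O)s2)cc1` gives 4300 nM, the only number so far. For compound 2 `CN(CCN)C(=O)c1cc(-c2ccccc2)sc1NC(N)=O` the entry reads "not determined" (no result reported), so compound 1 has no measured neighbour to stand against. Compound 3 `NC(=O)Nc1sc(-c2ccc(C(=O)N3CCCCC3)cc2)cc1C(=O)N[C@H]1CCCNC1` keeps the core of compound 1 and differs by piperidin-1-yl in place of methylamino on a carbonyl carbon, with piperidin-1-yl in place of methylamino on a carbonyl carbon. Among the measured compounds shown here, no measured pair shows this kind of change, so no step beyond the scatter in this assay is expected, and no direction is favoured. The expected change is a 1.2-fold lower number from compound 1 to compound 3 (0.09 log units; within the scatter). The estimate for compound 3 is 3500 nM, within a range of 1000 nM to 12000 nM.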

Compound 3, half-maximal effective concentration: 130 nM
For compound 3 the middle estimate is 27-fold (1.43 log units) above the measured one; the measured number lies below the stated range.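

On the carbonyl carbon, whose other neighbour is an aromatic carbon, the amide substituent matters in this assay: piperidin-1-yl in place of methylamino gives a 33-fold lower number from compound 1 to compound 3 (1.52 log units; beyond the scatter) and so moves the number well beyond the scatter. Methylamino carries a hydrogen-bond donor and piperidin-1-yl carries none while adding a six-membered non-aromatic ring, and this single pair cannot separate these differences. No evidence at hand bears on the origin of the step.

Open, as far as these compounds go, is whether dimethylamino, diethylamino or morpholin-4-yl at this place would give a step of similar size.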